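Working notes: from 4-methylpiperazin-1-yl to piperazin-1-yl

The source may report more compounds than this note shows. Statements on the series, on what has been measured and on what is new or still open speak of the compounds shown alone.

Compound 1 `CN(C)CCCCNc1nc2cc([N+](=O)[O-])ccc2nc1NCc1ccc(C(F)(F)F)cc1`: 9.73 ug/mL
Compound 2 `CN1CCN(c2nc3cc([N+](=O)[O-])ccc3nc2NCc2ccc(C(F)(F)F)cc2)CC1`: 6.99 ug/mL

Both values come from an ADME assay on HEK293 cells (Homo sapiens) for cytotoxicity, read by MTT assay, with a stated time of 24 h; a higher number here means a weaker inhibitor, a lower number a stronger inhibitor. Compound 2, at 6.99 ug/mL, lies within the scatter of compound 1, so neither ranks ahead of the other. The next compound to be read is compound 3 `O=[N+]([O-])c1ccc2nc(NCc3ccc(C(F)(F)F)cc3)c(N3CCNCC3)nc2c1`. Its difference from compound 2 is hydrogen in place of methyl on an amine nitrogen in a ring. Within the data shown here, no measured step removes this methyl, so the evidence is indirect. Among the measured compounds shown here, the one measured step, a 1.4-fold lower number from compound 1 to compound 2 (0.14 log units; within the scatter), exchanges the whole group on the aromatic carbon and stays within the scatter. On that basis, no shift beyond the scatter is expected in this assay for the smaller change. The estimated step is a 1.0-fold higher number from compound 2 to compound 3 (0.00 log units; within the scatter). Compound 3 is expected at 7 ug/mL, with an estimated range of 3.5 ug/mL to 14 ug/mL.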

Compound 3, half-maximal inhibitory concentration: 9.61 ug/mL
For compound 3 the middle estimate is 1.4-fold (0.14 log units) below the measured one; the range from low to high includes it.
By their numbers in this assay, from the lowest: compounds 2, 3 and 1 (each within the scatter of the next).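

In this assay, the methyl on the amine nitrogen in the ring now has a direct reading of its own (a 1.4-fold higher number from compound 2 to compound 3 (0.14 log units; within the scatter)): methyl and hydrogen at this position cannot be told apart. The exchange on the aromatic carbon gives the same picture with the unsubstituted ring (a 1.0-fold lower number from compound 1 to compound 3 (0.01 log units; within the scatter)), so piperazin-1-yl and (4-(dimethylamino)butyl)amino also cannot be told apart here. No supporting measurement is available to explain these readings.

Still open, going by these compounds, is whether a larger group on the ring nitrogen, such as an acetyl group or a longer chain ending in a carboxylic acid, would take the number beyond the scatter. The same question stands for a ring without the second nitrogen, such as morpholin-4-yl, on the aromatic carbon.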